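Moving a halogen around a benzyl thioether

The source may report more compounds than this note shows. Statements on the series, on what has been measured and on what is new or still open speak of the compounds shown alone.

Three compounds share one core and differ only in the group attached to a sulfur. Compound 1 `Nc1nc(SCc2cccc(Br)c2)c2ncn([C@@H]3O[C@H](CO)[C@@H](O)[C@H]3O)c2n1` carries a 3-bromobenzyl group, compound 2 `CCC(C)Sc1nc(N)nc2c1ncn2[C@@H]1O[C@H](CO)[C@@H](O)[C@H]1O` a sec-butyl group, and compound 3 `Nc1nc(SCc2ccccc2Cl)c2ncn([C@@H]3O[C@H](CO)[C@@H](O)[C@H]3O)c2n1` a 2-chlorobenzyl group. In an assay on isolated protein for binding affinity to Equilibrative nucleoside transporter 1 (Homo sapiens) (on this read-out lower numbers stand for stronger inhibition and higher numbers for weaker inhibition), compound 1 gives 2880 nM. In this assay compound 2 gives 63100 nM, and compound 3 gives 13500 nM. Among these three numbers compound 3 stands second highest: the nearest neighbour is seen in the step of a 4.7-fold lower number from compound 2 to compound 3 (0.67 log units; beyond the scatter), and the furthest in the step of a 4.7-fold higher number from compound 1 to compound 3 (0.67 log units; beyond the scatter). For comparison, the two ends of the set are joined by the step of a 22-fold higher number from compound 1 to compound 2 (1.34 log units; beyond the scatter).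

Compound 4 `Nc1nc(SCc2ccc(F)cc2)c2ncn([C@@H]3O[C@H](CO)[C@@H](O)[C@H]3O)c2n1` has not yet been measured in this assay. It differs from compound 3 in one place: 4-fluorophenyl in place of 2-chlorophenyl on a saturated chain carbon bound to a sulfur. Among the measured compounds shown here, no measured pair shows exactly this exchange. The step that bears on it most is a 4.7-fold higher number from compound 1 to compound 3 (0.67 log units; beyond the scatter), which shows that changing which halogen sits on the benzyl ring, and where, moves the number only modestly. Both halobenzyl compounds also sit well below compound 2, so a halobenzyl group seems to keep the number in the lower part of this range. A modest step is therefore expected, more likely downward than upward, expressed as a 1.9-fold lower number from compound 3 to compound 4 (0.29 log units; within the scatter). Compound 4 is expected to give about 7000 nM, within a range from 2000 nM to 25000 nM.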

Compound 4, half-maximal inhibitory concentration: 1150 nM
For compound 4 the middle estimate is 6.1-fold (0.78 log units) above the measured one; the measured number lies below the stated range.
By their numbers in this assay, from the lowest: compound 4; then compound 1; then compound 3; then compound 2.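

The exchange of 2-chlorophenyl for 4-fluorophenyl on a saturated chain carbon bound to a sulfur gives a large step (a 12-fold lower number from compound 3 to compound 4 (1.07 log units; beyond the scatter)), so the choice of halogen-bearing ring here can matter much more than the earlier halobenzyl pair indicated. The comparison with the other halobenzyl group is smaller but still beyond the scatter (a 2.5-fold lower number from compound 1 to compound 4 (0.40 log units; beyond the scatter)), while the change from sec-butyl gives the widest step in the set (a 55-fold lower number from compound 2 to compound 4 (1.74 log units; beyond the scatter)), leaving the lowest number of the four with the 4-fluorobenzyl group. Nothing shown here gives a measured reason for these differences.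

The halogen and its place on the ring change together in each halobenzyl pair, so the compounds shown cannot say how much of the large step belongs to fluorine replacing chlorine and how much to where the halogen sits. They also leave open how a plain benzyl group, or a benzyl ring carrying a methoxy group or an amine instead of a halogen, would compare on the same shared core.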